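Chloro for methyl on the aroyl group of compound 1

This account rests on a few compounds, and the source may have more. Where it says the series, first, only, none or still open, it means among the compounds named here.

Measured so far in an ADME assay on HEK-293T cells (Homo sapiens) for cytotoxicity, read by MTT assay, with a stated time of 24 h; on this read-out lower numbers stand for higher toxicity in this test and higher numbers for lower toxicity in this test:
- compound 1, `Cc1ccc(C(=O)n2c(-c3cn(-c4ccccc4)nc3-c3ccc(C(F)(F)F)cc3)nc3ccccc32)cc1`, 169000 nM
- compound 2, `Cc1ccc(C(=O)n2c(-c3cn(-c4ccccc4)nc3-c3ccc(F)cc3)nc3ccccc32)cc1`, 178000 nM
- compound 3, `Cc1ccc(-c2nn(-c3ccccc3)cc2-c2nc3ccccc3n2C(=O)c2ccccc2)cc1`, 204000 nM

In this assay compound 1 gives 169000 nM; the numbers for compound 2 and compound 3 sit within the scatter of it, so the three cannot be told apart. Within the data shown here, the one single-point step measured, a 1.1-fold higher number from compound 1 to compound 2 (0.02 log units; within the scatter), concerns the other aryl group and was within the scatter.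

Compound 4, `O=C(c1ccc(Cl)cc1)n1c(-c2cn(-c3ccccc3)nc2-c2ccc(C(F)(F)F)cc2)nc2ccccc21`, differs from compound 1 by chloro in place of methyl on an aromatic carbon. Among the measured compounds shown here, no measured step touches this aroyl position, and the one step that exists elsewhere did not move the number. On that basis compound 4 is expected to sit within the scatter of compound 1, with an estimated step of a 1.0-fold higher number from compound 1 to compound 4 (0.00 log units; within the scatter). The estimate for compound 4 in this assay is 170000 nM, in the range 85000 nM to 340000 nM.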

Compound 4, half-maximal cytotoxic concentration: 181000 nM
Beside the measured number, compound 4's estimate is 1.1-fold (0.03 log units) below it; the measured number falls inside the stated range.
By their numbers in this assay, from the lowest: compounds 1, 2, 4 and 3 (each within the scatter of the next).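

In this assay the aroyl position now has its first measured step: a 1.1-fold higher number from compound 1 to compound 4 (0.03 log units; within the scatter) for 4-methylphenyl to 4-chlorophenyl on the carbonyl. With a 1.1-fold higher number from compound 1 to compound 2 (0.02 log units; within the scatter) on the other aryl group, each of these two aryl groups now has one single-point step, and neither step separates its two compounds. No available evidence bears on this result.

Going by these compounds, whether an amine or a carboxylic acid on this aromatic carbon would give a number beyond the scatter of compound 1 remains open. Also open, on these data alone, is whether chloro in place of methyl would read the same with fluoro rather than trifluoromethyl on the other aryl group, the form that compound 2 carries.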